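The source may hold more compounds than are shown below. What is called first, only, known or untested is meant among the compounds shown, and "the series" means these compounds.

Measured in a functional assay on brain (Rattus norvegicus, strain Wistar) for inhibition; a higher number here means a weaker inhibitor, a lower number a stronger inhibitor:
- compound 1 `CCCCc1ccc(-c2c(CC)[nH]c(=O)n2C)cc1` gives 13900 nM
- compound 2 `CCCCn1c(-c2ccccc2)c(C)[nH]c1=O` gives > 100000 nM
- compound 3 `CCCCc1ccc(-c2c(C)[nH]c(=O)n2CCCC)cc1` gives 12000 nM

The entry for compound 2 is a limit of the assay, not a number. Among the compounds with values here, compound 3 lies within the scatter of compound 1, the only other true number. Compound 4 `CCCCc1ccc(-c2c(C)[nH]c(=O)n2-c2ccccc2)cc1` has phenyl in place of butyl on an aromatic nitrogen. Within the data shown here, the one measured step, an at least 8.3-fold lower number from compound 2 to compound 3 (0.92 log units; beyond the scatter), placed butyl on an aromatic carbon, and compound 4 keeps that group, so it says little about this change. Compound 1 carries a smaller group on that nitrogen and differs elsewhere too, yet it gives 13900 nM. No step beyond the scatter is therefore expected in this assay, though with wide uncertainty. The estimated step is a 1.3-fold higher number from compound 3 to compound 4 (0.10 log units; within the scatter). For compound 4 the expected value is 15000 nM, with an estimated range from 4000 nM to 60000 nM.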

Compound 4, half-maximal inhibitory concentration: 16600 nM
For compound 4 the middle estimate is 1.1-fold (0.04 log units) below the measured one; the measured number falls inside the stated range.
By their numbers in this assay, from the lowest: compounds 3, 1 and 4 (each within the scatter of the next). At a limit, above all of these: compound 2.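

In this assay, phenyl in place of butyl on an aromatic nitrogen gives a 1.4-fold higher number from compound 3 to compound 4 (0.14 log units; within the scatter). Within the data shown here, this is the first direct reading at this position: a six-membered aromatic ring and a butyl chain cannot be told apart here, so this swap shows no step beyond the scatter. Compound 2 alone stands at a limit of the assay, which is not a number: the limit of > 100000 nM in this assay, at which 1 of the 4 values shown sits.

From the compounds shown here alone, whether an amine, a carboxylic acid or a longer chain on this nitrogen would fit as well stays open. Compound 1 differs from compound 3 in more than one place, so the effect of a smaller group there cannot be read alone.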